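Compound 3 to compound 4: exchange on an aromatic nitrogen

The source may hold more compounds than are shown below. What is called first, only, known or untested is meant among the compounds shown, and "the series" means these compounds.

compound 1 `CCOC(=O)c1ccc(NC(=O)CSc2ncncc2-c2cccc3ccccc23)c(Cl)c1` gives 195000 nM
compound 2 `O=C(CSc1ncncc1-c1cccc2ccccc12)Nc1ccc(C(=O)O)cc1Cl` gives 108000 nM
compound 3 `O=C(O)c1ccc(-n2cc(CSc3ncncc3-c3cccc4ccccc34)nn2)cc1` gives 95900 nM

In an ADME assay on MT4 cells (Homo sapiens) for cytotoxicity, read by MTT assay (a lower number here means that less compound is tolerated, a higher number that more compound is tolerated), compound 3 at 95900 nM lies within the scatter of compound 2 at 108000 nM while compound 1 at 195000 nM gives a higher number than compound 3, beyond the scatter.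

Compound 4 `Brc1ccccc1Cn1cc(CSc2ncncc2-c2cccc3ccccc23)nn1` is still unmeasured. It carries 2-bromobenzyl in place of 4-carboxyphenyl on an aromatic nitrogen and keeps the rest of compound 3.

For the measured compounds named here, the one measured step is a 1.8-fold lower number from compound 1 to compound 2 (0.26 log units; within the scatter) and it concerns a different change, hydrogen in place of ethyl. Going by the values given here, no measured step exchanges a group on that nitrogen, which makes this thin guidance. No step beyond the scatter is expected, though with wide uncertainty and no firm direction. The estimated step is a 1.4-fold lower number from compound 3 to compound 4 (0.14 log units; within the scatter) on this limited evidence.

For compound 4 the expected value is 70000 nM with 15000 nM and 200000 nM as the estimated bounds.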

Compound 4, half-maximal cytotoxic concentration: 39400 nM
The estimate for compound 4 lay 1.8-fold (0.25 log units) above the measured number; the range from low to high includes it.
By their numbers in this assay, from the lowest: compound 4; then compounds 3, 2 and 1 (each within the scatter of the next, the first and the last beyond it).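

In this assay, for the compounds shown here, 2-bromobenzyl in place of 4-carboxyphenyl on the aromatic nitrogen gives a 2.4-fold lower number from compound 3 to compound 4 (0.39 log units; beyond the scatter) and is the only single-place change so far to pass the scatter, so the group on this nitrogen can shift the tolerated concentration. The exchange changes several features at once: 4-carboxyphenyl, with its hydrogen-bond donor and acceptor, leaves, while 2-bromobenzyl enters with bromine and neither. Nothing available explains the step.

Still open, on these data alone, is which of these features carries the step, and a single exchange cannot separate them. A plain benzyl, a phenyl without the carboxylic acid, or a group holding an amine on the same nitrogen would help to show whether the bromine, the acid or the benzyl link matters.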